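A few compounds are considered here, and "the series" means these few. Any claim that something is new, unique, unknown or untested is made for them only; others in the source may bear on it.

Measured compounds:
Compound 1 `C/C(=N\Nc1nc(-c2ccc(Cl)cc2)cs1)c1cc2ccccc2o1`, which in a functional assay on HepG2 cells (Homo sapiens) for antiproliferative activity (on this read-out lower numbers stand for stronger inhibition and higher numbers for weaker inhibition), gives 23200 nM.
Compound 2 `C/C(=N\Nc1nc(-c2cc3ccccc3o2)cs1)c1cc2ccccc2o1`, which in this assay gives 21300 nM.

Compound 2 holds the lowest of the two numbers, but the gap to its nearest neighbour, a 1.1-fold lower number from compound 1 to compound 2 (0.04 log units; within the scatter), lies within the scatter, so the two compounds stand level. Compound 3 `C/C(=N\Nc1nc(C)cs1)c1cc2ccccc2o1` has not yet been measured. It differs from compound 2 by methyl in place of 1-benzofuran-2-yl on an aromatic carbon.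

Within the data shown here, only one measured step exists that bears on this change, a 1.1-fold lower number from compound 1 to compound 2 (0.04 log units; within the scatter): there one aromatic group replaced another on the same carbon, and the number barely moved. Among the measured compounds shown here, the step to compound 3 is of a different kind, since a large group leaves and a methyl enters at that carbon, and no measured pair shows what such a reduction does here. The two measured values show that this position tolerates one aromatic group as well as another, nothing more. The expectation for compound 3 is therefore a modest rise in the number, a 1.6-fold higher number from compound 2 to compound 3 (0.22 log units; within the scatter), with wide uncertainty. For compound 3 in this assay the estimate is 35000 nM, between 12000 nM and 100000 nM.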

Compound 3, half-maximal inhibitory concentration: 4000 nM
Estimate against measurement, compound 3: 8.8-fold (0.94 log units) above; the whole stated range lies above it.
By their numbers in this assay, from the lowest: compound 3; then compounds 2 and 1 (each within the scatter of the next).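

In this assay, methyl in place of 1-benzofuran-2-yl on the aromatic carbon next to the ring nitrogen gives a 5.3-fold lower number from compound 2 to compound 3 (0.73 log units; beyond the scatter) and so lies well outside the level stretch seen so far, while methyl in place of 4-chlorophenyl at the same carbon gives a 5.8-fold lower number from compound 1 to compound 3 (0.76 log units; beyond the scatter) in the same direction. The position that looked indifferent when one aromatic group replaced another therefore does respond when the aromatic group gives way to a single carbon, and compound 3, with no ring at this carbon, holds the strongest inhibition of the three compounds on this read-out. Nothing available gives a reason for this shift.

On these data alone, with only methyl and two large aromatic groups on show at this carbon, it remains open whether the number follows the size of the group in a steady way or whether any aromatic group at all sets the higher level. Hydrogen, ethyl, cyclopropyl or an unsubstituted phenyl at this carbon would help to separate these readings, and an amine or a carboxylic acid there would show how far the trend extends beyond simple carbon groups.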